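Methoxy on the benzoyl ring across two cinnamoyl hydrazide cores

The source may hold more compounds than are shown below. What is called first, only, known or untested is meant among the compounds shown, and "the series" means these compounds.

Measured compounds in a functional assay on MCF7 cells (Homo sapiens) for antiproliferative activity, read by MTT assay, with a stated time of 24 h; on this read-out higher numbers stand for weaker inhibition and lower numbers for stronger inhibition:
compound 1, `O=C(/C=C/c1ccc(O)cc1)NNC(=O)c1ccccc1`: 7390 nM
compound 2, `COc1ccc(C(=O)NNC(=O)/C=C/c2ccc(O)cc2)cc1`: 6020 nM
compound 3, `COc1cc(/C=C/C(=O)NNC(=O)c2ccccc2)cc(OC)c1O`: > 10000 nM

Compound 1 and compound 2 share one core, and in this assay compound 1 gives 7390 nM while compound 2 gives 6020 nM. The change between them is methoxy in place of hydrogen on an aromatic carbon and it produced a 1.2-fold lower number from compound 1 to compound 2 (0.09 log units; within the scatter), so the two values cannot be told apart.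

Compound 3 rests on a different core, and the difference between the two cores is not broken down here. For compound 3 this assay reports only a limit, > 10000 nM, as noted in the limit of > 10000 nM in this assay, at which 1 of the 3 values shown sits.

Compound 4, `COc1ccc(C(=O)NNC(=O)/C=C/c2cc(OC)c(O)c(OC)c2)cc1`, has not yet been tested. Going by the values given here, it differs from compound 3 by methoxy in place of hydrogen on an aromatic carbon, which is the same change as the one from compound 1 to compound 2, made at the same place on the same kind of ring. Because that earlier change gave a 1.2-fold lower number from compound 1 to compound 2 (0.09 log units; within the scatter), the step from compound 3 to compound 4 is expected to be small as well, estimated at a step that the limit leaves unreadable from compound 3 to compound 4. Since compound 3 is known only as a limit, > 10000 nM, compound 4 is expected most likely to come out as a limit too, and its value is estimated at 12000 nM, with a plausible range from 5000 nM to 30000 nM.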

Compound 4, half-maximal inhibitory concentration: 7170 nM
For compound 4 the middle estimate is 1.7-fold (0.22 log units) above the measured one; low and high end bracket the measured number.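

Carried onto the core of compound 3, the change from phenyl to 4-methoxyphenyl gave an at least 1.3-fold lower number from compound 3 to compound 4 (0.14 log units; that floor lies within the scatter) in this assay. Set beside the same change on the core of compound 1, this step cannot be told apart from the earlier one: the same change on two cores in this assay, a 1.2-fold lower number (0.09 log units; within the scatter) from compound 1 to compound 2 and an at least 1.3-fold lower number (0.14 log units; that floor lies within the scatter) from compound 3 to compound 4; the limit leaves it open whether they differ

On these data alone, the value of compound 3 is only a limit, > 10000 nM, and the true size of the step on its core remains unknown, which means the two cores neither show that the change carries over with the same size nor show that it behaves differently from one core to the other.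

The compounds shown leave open what other groups would do at the same place on the ring, for example an amine, a carboxylic acid or a longer chain such as butoxy in place of the methoxy. They also leave open whether any such group would give a step beyond the usual scatter on either core, and whether that step would then match from the core of compound 1 to the core of compound 3.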